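A few compounds are considered here, and "the series" means these few. Any claim that something is new, unique, unknown or untested is made for them only; others in the source may bear on it.

Measured so far:
compound 1 `Nc1scc(CN2CCN(c3ccc(OC(F)(F)F)cc3)CC2)c1C(=O)c1ccc(Cl)cc1` — in a functional assay on CHO cells with adenosine receptor A1 (Homo sapiens) as the target, read by cAMP accumulation and immunoassay, with a stated time of 6 min, tested at 0.1 uM (a lower number here means a stronger effect, a higher number a weaker effect of the compound at the concentration tested), compound 1 gives -13%
compound 2 `Nc1scc(CN2CCN(c3cccc4ccccc34)CC2)c1C(=O)c1ccc(Cl)cc1` — in this assay compound 2 gives 0%

Compound 2 stands highest of the two numbers; the only other, compound 1, lies lower. That step, a number 13 percentage points higher from compound 1 to compound 2 (beyond the scatter), is modest. Compound 3 `Nc1scc(CN2CCN(c3ccccc3F)CC2)c1C(=O)c1ccc(Cl)cc1` carries 2-fluorophenyl in place of naphthalen-1-yl on an amine nitrogen in a ring. Within the data shown here, the one measured step that bears on this is the exchange of the group on the same ring nitrogen, a number 13 percentage points higher from compound 1 to compound 2 (beyond the scatter). With both known numbers near zero in this assay, no step beyond the scatter is expected in either direction, though a modest one would not surprise. Compound 3 is therefore estimated at -5%, in the range -22% to 12%. The expected step is a number 5 percentage points lower from compound 2 to compound 3 (within the scatter).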

Compound 3, a percentage reported as activity, at one concentration (the size of the read-out at that concentration, not a potency): -1%
The estimate for compound 3 lay 4 percentage points below the measured number; low and high end bracket the measured number.
By their numbers in this assay, from the lowest: compound 1; then compounds 3 and 2 (each within the scatter of the next).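

In this assay, 2-fluorophenyl in place of naphthalen-1-yl on the ring nitrogen gives a number 1 percentage points lower from compound 2 to compound 3 (within the scatter), so one aromatic ring and two read the same here. Against 4-(trifluoromethoxy)phenyl the same group gives a number 12 percentage points higher from compound 1 to compound 3 (beyond the scatter), which leaves compound 1 apart from both compound 2 and compound 3, although only modestly. No supporting evidence explains these differences. Still open, going by these compounds, is whether an unsubstituted phenyl, a pyridyl ring or an acetyl group on this nitrogen would move the read-out clearly away from these values.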